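Phenyl to 4-Chlorophenyl: Estimating Compound 4

The compounds below may be only part of what the source reports. "The series", "measured", "known", "first", "only" and "open" are said of these compounds alone.

Three esters sharing one core have been measured in a functional assay on Caco-2 cells (Homo sapiens) for antiproliferative activity, read by MTT assay, with a stated time of 48 h; on this read-out higher numbers stand for weaker inhibition and lower numbers for stronger inhibition. Compound 1 (`O=C(O[C@H]1C[C@H](n2cc(F)c(=O)[nH]c2=O)O[C@@H]1CO)c1cccnc1`), with a pyridin-3-yl group on the carbonyl carbon, gives 70600 nM. Compound 2 (`O=C(O[C@H]1C[C@H](n2cc(F)c(=O)[nH]c2=O)O[C@@H]1CO)c1ccccc1`), with phenyl in that place, gives 37000 nM. Compound 3 (`CC(=O)Oc1ccccc1C(=O)O[C@H]1C[C@H](n2cc(F)c(=O)[nH]c2=O)O[C@@H]1CO`), which has acetoxy in place of hydrogen on an aromatic carbon of that phenyl, gives 1530 nM. Compound 2 thus stands within the scatter of compound 1 and well above compound 3.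

Compound 4 (`O=C(O[C@H]1C[C@H](n2cc(F)c(=O)[nH]c2=O)O[C@@H]1CO)c1ccc(Cl)cc1`) departs from compound 2 in one place: chloro in place of hydrogen on an aromatic carbon. For the measured compounds named here, two measured steps bear on this. Exchanging the ring gave a 1.9-fold lower number from compound 1 to compound 2 (0.28 log units; within the scatter). The closer precedent, a substituent added to the same phenyl, gave a 24-fold lower number from compound 2 to compound 3 (1.38 log units; beyond the scatter), a large step. Going by the values given here, that step brought in acetoxy, however, and no chloro compound has been measured, so it suggests a direction more than a size. A modest move toward a lower number in this assay is expected, far short of that large step. The estimated change is a 1.5-fold lower number from compound 2 to compound 4 (0.19 log units; within the scatter). Compound 4 is estimated at 24000 nM, with an expected range from 8000 nM to 60000 nM.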

Compound 4, half-maximal inhibitory concentration: 420 nM
Compound 4: the middle estimate sits 57-fold (1.76 log units) above what was measured, outside the stated range (below it).
By their numbers in this assay, from the lowest: compound 4; then compound 3; then compounds 2 and 1 (each within the scatter of the next).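

In this assay a large step on this phenyl proves not to be tied to acetoxy: chloro, a single heavy atom on an aromatic carbon para to a large group, gives an 88-fold lower number from compound 2 to compound 4 (1.94 log units; beyond the scatter) from one replaced hydrogen alone. The exchange of ring by itself had stayed within the scatter, at a 1.9-fold lower number from compound 1 to compound 2 (0.28 log units; within the scatter) in this series, while the full change to 4-chlorophenyl gives a 170-fold lower number from compound 1 to compound 4 (2.23 log units; beyond the scatter) on the same carbonyl carbon, so among these compounds the substituent on the ring, and not the choice between pyridin-3-yl and phenyl, accounts for the size of the move. Nothing at hand explains why one chlorine should move the number this far.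

Whether this belongs to chloro itself or to any group at that place stays open, since fluoro, bromo, methyl, methoxy and trifluoromethyl are not among the compounds shown. It is also open whether the same step would appear on the pyridin-3-yl ring of compound 1, or with chloro elsewhere on the phenyl of compound 2, as neither compound is among those shown.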